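Cyclohexyl in place of 4-bromophenyl: compound 3 to compound 4

The source may report more compounds than this note shows. Statements on the series, on what has been measured and on what is new or still open speak of the compounds shown alone.

Compound 3 (`Cn1c(-c2ccccc2)cnc1NC(=O)c1ccc(Br)cc1`) gives > 100000 nM in a toxicity assay on THP-1 cells (Homo sapiens) for inhibition (on this read-out lower numbers stand for higher toxicity in this test and higher numbers for lower toxicity in this test), and that value is a limit, not a number. Compound 1 (`Cc1ccccc1C(=O)Nc1ncc(-c2ccccc2)n1C`) gives > 100000 nM in this assay and this too is a limit. Compound 2 (`COc1ccc(-c2cnc(NC(=O)c3ccc(Br)cc3)n2C)cc1`) gives > 100000 nM in this assay and this is also a limit.

The change now in question is carried by compound 4 (`Cn1c(-c2ccccc2)cnc1NC(=O)C1CCCCC1`) and is counted as follows (cyclohexyl in place of 4-bromophenyl on a carbonyl carbon) on a carbonyl carbon whose other neighbour is the amide-type nitrogen.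

Going by the values given here, two measured steps bear on it. The closer is a step that the two limits leave unreadable from compound 1 to compound 3 with 4-bromophenyl in place of 2-methylphenyl on a carbonyl carbon, the same place as the new change. The other is a step that the two limits leave unreadable from compound 2 to compound 3 with hydrogen in place of methoxy on an aromatic carbon. Neither gives a size to carry over. The expectation for compound 4 therefore rests on compound 3 sitting with the others at the limit of > 100000 nM in this assay, at which 3 of the 3 values shown sit, and on nothing more. No step beyond the scatter is expected and the estimated move is a number no higher from compound 3 to compound 4 (the limit leaves the size open) with no direction favoured. Compound 4 is estimated at 100000 nM with an expected range from 50000 nM to 200000 nM and a further limit is the likeliest report.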

Compound 4, half-maximal cytotoxic concentration: > 100000 nM
Compound 4 was reported as a limit (the forecaster's own chance of this, stated with the estimate: 85%); the middle value sits exactly at the limit.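

Compound 4 stands at a limit, as do compound 1 and compound 3, so neither step to compound 4 can be read in this assay: the limit of > 100000 nM in this assay, at which 4 of the 4 values shown sit.

The compounds shown leave open whether any group on the carbonyl carbon gives a readable value rather than a limit in this assay, and how large such a step would be.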